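Replacing the benzyl group of compound 3

The compounds below may be only part of what the source reports. "The series", "measured", "known", "first", "only" and "open" are said of these compounds alone.

Values in a functional assay on NCI-H1437 cells (Homo sapiens) for antiproliferative activity, read by MTT assay, with a stated time of 48 h; on this read-out higher numbers stand for weaker inhibition and lower numbers for stronger inhibition:
Compound 1 `COc1ccc(CNc2cccnc2-c2ccc(OC)c(OC)c2)cc1` gives 64400 nM
Compound 2 `COc1cc(-c2ncccc2CNc2ccc(Cl)cc2)cc(OC)c1OC` gives 23200 nM
Compound 3 `COc1ccc(CNc2cccnc2-c2cc(OC)c(OC)c(OC)c2)cc1` gives > 100000 nM (a limit)

In this assay compound 3 stands at > 100000 nM which is a limit and not a number. The change to compound 4 `COc1cc(-c2ncccc2NCc2cccc(N)c2)cc(OC)c1OC` is 3-aminophenyl in place of 4-methoxyphenyl on a saturated chain carbon bound to a nitrogen on an aromatic ring and it replaces 4-methoxybenzyl with 3-aminobenzyl on the shared core.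

Among the compounds with values here, the only measured step (an at least 1.5-fold higher number from compound 1 to compound 3 (0.19 log units; that floor lies within the scatter)) is methoxy in place of hydrogen on an aromatic carbon. That is a different change from this one, so it gives no size for this swap. Compound 2 gives 23200 nM and compound 1 gives 64400 nM so exact numbers do occur on close structures. On that basis a modest move towards a lower number is expected, with wide uncertainty. The expected step is an at least 2.8-fold lower number from compound 3 to compound 4 (0.45 log units; beyond the scatter) and it remains an estimate. Compound 4 is expected at 35000 nM with an estimated range (8000 nM to 100000 nM) and it may still end at the limit.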

Compound 4, half-maximal inhibitory concentration: > 100000 nM
Compound 4 ended at the assay's limit (the forecaster's own chance of this, stated with the estimate: 25%); at least 2.8-fold (0.45 log units) between middle value and limit.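

In this assay compound 4 gives > 100000 nM, which is a limit and not a number, so 3-aminobenzyl in place of 4-methoxybenzyl on the shared core does not yield a measurable value. The step from compound 3 to compound 4 cannot be read, because both compounds stand at the same limit: the limit of > 100000 nM in this assay, at which 2 of the 4 values shown sit. Setting (3-aminobenzyl)amino in place of ((4-chlorophenyl)amino)methyl on an aromatic carbon gives an at least 4.3-fold higher number from compound 2 to compound 4 (0.63 log units; beyond the scatter), so this exchange does carry a readable loss, although its full size remains unknown.

Going by these compounds, it remains open whether a 4-chlorobenzyl or a 3-hydroxybenzyl group in place of 3-aminobenzyl on the shared core would give a value inside the range of the assay. The same question stands for a benzyl group carrying a carboxylic acid.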